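The compounds below may be only part of what the source reports. "The series", "measured", "known", "first", "only" and "open" are said of these compounds alone.

Compound 1 `C[C@@H](CN1CCc2cc(F)ccc21)NC(=O)O[C@@H](CC1CCCCC1)C(=O)N1CCOCC1`, compound 2 `O=C(N[C@@H](CCc1ccccc1)CNc1ccc(OC(F)(F)F)cc1)O[C@@H](CC1CCCCC1)C(=O)N1CCOCC1` and compound 3 `C[C@@H]1CN(C(=O)[C@H](CC2CCCCC2)OC(=O)N[C@@H](C)CN2CC(C)(C)c3cc(F)ccc32)C[C@H](C)O1` share a core and differ at both ends. In an assay on isolated protein for inhibition of cathepsin S (Homo sapiens) (a higher number here means a weaker inhibitor, a lower number a stronger inhibitor), compound 1 gives 226 nM, compound 2 gives 18 nM and compound 3 gives 297 nM. Compound 3 has the highest number of the three, but its gap to compound 1 lies within the usual scatter, so the two cannot be told apart; only the gap to compound 2, whose number is lower, lies beyond the scatter.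

Compound 4 `C[C@@H](CN1CC(C)(C)c2cc(F)ccc21)NC(=O)O[C@@H](CC1CCCCC1)C(=O)N1CCCC1` is not yet measured. It differs from compound 3 in one place: pyrrolidin-1-yl in place of 2,6-dimethylmorpholin-4-yl on a carbonyl carbon. For the measured compounds named here, no pair of measured compounds differs by this change alone, so nothing in the data sets its size. Given that the group being exchanged sits away from the part where compound 1 and compound 3 agree within the scatter, the step from compound 3 to compound 4 is expected to stay within the scatter, estimated as a 1.4-fold lower number from compound 3 to compound 4 (0.13 log units; within the scatter) in this assay. Compound 4 is therefore estimated at 220 nM, with a range from 70 nM to 700 nM.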

Compound 4, inhibition constant: 56 nM
Beside the measured number, compound 4's estimate is 3.9-fold (0.59 log units) above it, and the stated range ends above it.
By their numbers in this assay, from the lowest: compound 2; then compound 4; then compounds 1 and 3 (each within the scatter of the next).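

For the compounds shown here, the group on this carbonyl carbon clearly matters in this assay: pyrrolidin-1-yl in place of 2,6-dimethylmorpholin-4-yl gives a 5.3-fold lower number from compound 3 to compound 4 (0.72 log units; beyond the scatter), the first single-place step in this set whose size can be read, and it lies beyond the scatter. The two groups differ in several ways at once, with 5 heavy atoms against 8, a five-membered ring against a six-membered one, and 0 hydrogen-bond acceptors against 1, so this one step cannot separate these differences. No supporting measurement is available to explain the step.

With the rest of compound 4 kept, a piperidin-1-yl or an unsubstituted morpholin-4-yl group on this carbonyl carbon could help separate ring size from the ring oxygen and the two methyl groups. On these data alone, whether the step carries over to the other ends seen in compound 1 and compound 2 also remains open.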